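A few compounds are considered here, and "the series" means these few. Any claim that something is new, unique, unknown or untested is made for them only; others in the source may bear on it.

In an assay on isolated protein with Bile acid receptor (Homo sapiens) as the target (on this read-out lower numbers stand for an effect already at smaller amounts and higher numbers for an effect only at larger amounts of compound), compound 1 `CCOc1cccc(-c2ccc(CN(C(=O)C3CCCCC3)c3cccc(/C=C/C(=O)OC)c3)cc2)c1` gives 147 nM. Compound 2 `COC(=O)/C=C/c1cccc(N(Cc2cccc(Br)c2)C(=O)C2CCCCC2)c1` reaches only the limit of this assay, reported as > 1000 nM; this is a boundary and not a number, as shown by the limit of > 1000 nM in this assay, at which 1 of the 2 values shown sits. Compound 3 `COC/C=C/c1ccc(CN(C(=O)C2CCCCC2)c2cccc(/C=C/C(=O)OC)c2)cc1` has not yet been measured. It differs from compound 2 in one place: 4-(3-methoxyprop-1-en-1-yl)phenyl in place of 3-bromophenyl on a saturated chain carbon bound to an amide-type nitrogen. Since compound 1, which also carries a larger group at that place, gives 147 nM, a gain beyond the scatter is expected, about an at least 3.3-fold lower number from compound 2 to compound 3 (0.52 log units; beyond the scatter). Compound 3 is expected to give roughly 300 nM, likely between 80 nM and 1500 nM.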

Compound 3, half-maximal effective concentration: 233 nM
Estimate against measurement, compound 3: 1.3-fold (0.11 log units) above, and the stated range covers the measured number.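

In this assay, replacing 3-bromophenyl with 4-(3-methoxyprop-1-en-1-yl)phenyl gives an at least 4.2-fold lower number from compound 2 to compound 3 (0.63 log units; beyond the scatter). Placing 3-methoxyprop-1-en-1-yl instead of 3-ethoxyphenyl on an aromatic carbon gives a 1.6-fold higher number from compound 1 to compound 3 (0.20 log units; within the scatter), so a second aromatic ring at that spot is not required for this level of effect, and the two groups cannot be told apart here. Compound 2 gives a limit and not a number: the limit of > 1000 nM in this assay, at which 1 of the 3 values shown sits.

Going by these compounds, whether the oxygen of the methoxy group contributes remains open. So does how an amine or a carboxylic acid would behave in its place.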